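This account rests on a few compounds, and the source may have more. Where it says the series, first, only, none or still open, it means among the compounds named here.

In an ADME assay on liver (Homo sapiens) for metabolic stability, read by LC-MS, using microsomes and NADPH, with a stated time of 15 min, tested at 1 uM (on this read-out higher numbers stand for fast clearance and lower numbers for slow clearance), compound 1 (`C[C@@H]1CN(Cc2ccccc2)c2nc(C(F)(F)F)ccc2[C@H](C)N1C(=O)NCc1ccccc1`) gives 531 mL.min-1.g-1. Compound 3 (`COc1ccc(CNC(=O)N2[C@H](C)CN(Cc3ccc(C(F)(F)F)o3)c3cnccc3[C@@H]2C)cc1`) differs from compound 1 in more than one place. Compound 3 gives 119 mL.min-1.g-1. Compound 2 (`C[C@@H]1CN(Cc2ccccc2)c2nc(F)ccc2[C@H](C)N1C(=O)NCc1ccccc1`) reads > 1250 mL.min-1.g-1, and this is a limit of the assay, not a number. Compound 2 therefore stands at the limit of > 1250 mL.min-1.g-1 in this assay, at which 1 of the 3 values shown sits.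

Compound 4 (`C[C@@H]1CN(Cc2ccccc2)c2ncccc2[C@H](C)N1C(=O)NCc1ccccc1`) follows from compound 2 by one change, hydrogen in place of fluoro on an aromatic carbon, next to the ring nitrogen. Within the data shown here, the one measured step that bears on this change concerns a group on an aromatic carbon, and it is an at least 2.3-fold higher number from compound 1 to compound 2 (0.37 log units; beyond the scatter), a step beyond the scatter. Among the measured compounds shown here, no measured compound of this pair's close family carries hydrogen at this carbon, so the direction of the new step cannot be read from the data.

For the measured compounds named here, with only that step as a guide, compound 4 is expected to remain fast-clearing alongside compound 2, with no step beyond the scatter expected in this assay. In numbers, the expected change is an at least 1.2-fold lower number from compound 2 to compound 4 (0.09 log units; that floor lies within the scatter). For compound 4 the estimated value is 1000 mL.min-1.g-1, with an expected range from 450 mL.min-1.g-1 to 1250 mL.min-1.g-1.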

Compound 4, intrinsic clearance in microsomes: 1060 mL.min-1.g-1
Compound 4: the middle estimate sits 1.1-fold (0.03 log units) below what was measured; low and high end bracket the measured number.
By their numbers in this assay, from the lowest: compound 3; then compounds 1 and 4 (each within the scatter of the next). At a limit, above all of these: compound 2.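

On this aromatic carbon, next to the ring nitrogen, hydrogen in place of trifluoromethyl gives in this assay a 2.0-fold higher number from compound 1 to compound 4 (0.30 log units; within the scatter), so the trifluoromethyl group and hydrogen cannot be told apart here, whereas fluoro in place of trifluoromethyl had given a step beyond the scatter. Hydrogen in place of fluoro gives an at least 1.1-fold lower number from compound 2 to compound 4 (0.07 log units; that floor lies within the scatter), and this floor does not show that the two groups differ, so the compounds shown give no firm order between fluoro and hydrogen at this carbon. The reading for compound 2 remains a limit of the assay and not a number: the limit of > 1250 mL.min-1.g-1 in this assay, at which 1 of the 4 values shown sits.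

The compounds shown leave open whether a methoxy group, an amine or a nitrile on this carbon would move the intrinsic clearance beyond the scatter from the numbers of compound 1 and compound 4. As far as these compounds go, compound 3, at 119 mL.min-1.g-1, differs from compound 1 in more than one place, so it remains open which of its changes, taken alone, would shift the number in this assay.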